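The source may hold more compounds than are shown below. What is called first, only, known or untested is meant among the compounds shown, and "the series" means these compounds.

Measured in a physicochemical assay for solubility; on this read-out lower numbers stand for lower solubility and higher numbers for higher solubility:
- Compound 1 `CNC(=O)c1cc(C(=O)NC2CC2)cn(Cc2cccc(F)c2)c1=O`: >= 133 ug/mL, a limit and not a number.
- Compound 2 `CNC(=O)c1cc(C(=O)NC2CC2)cn([C@H](C)c2ccccc2)c1=O`: >= 168 ug/mL, a limit and not a number.
- Compound 3 `CNC(=O)c1cc(C(=O)NC2CC2)cn(Cc2cccc3[nH]ccc23)c1=O`: 78 ug/mL.

Compound 3 is the only one of the three with an actual number, 78 ug/mL. The other two values are limits. The next compound, compound 4 `CNC(=O)c1cc(C(=O)NC2CC2)cn(Cc2cccc(C)c2)c1=O`, carries 3-methylphenyl in place of 1H-indol-4-yl on a saturated chain carbon bound to an aromatic nitrogen.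

The closest guide is an at least 1.7-fold lower number from compound 1 to compound 3 (0.23 log units; that floor lies within the scatter), where 1H-indol-4-yl replaced 3-fluorophenyl at that same place. The other measured change, to 1-phenylethyl, is a step that the two limits leave unreadable from compound 1 to compound 2 and gives no guide. Compound 4 runs the opposite way to the change that gave compound 3, so a modest rise in this assay is expected, though it may stay within the scatter.

The expected change is a 1.5-fold higher number from compound 3 to compound 4 (0.19 log units; within the scatter). For compound 4 the estimated solubility is 120 ug/mL, with an expected range of 60 ug/mL to 220 ug/mL.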

Compound 4, solubility: >= 205 ug/mL
Compound 4 gave a limit, no number (the forecaster's own chance of this, stated with the estimate: 50%); middle value at least 1.7-fold (0.23 log units) away from the limit.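

In this assay, 3-methylphenyl in place of 1H-indol-4-yl on the saturated chain carbon gives an at least 2.6-fold higher number from compound 3 to compound 4 (0.41 log units; beyond the scatter), so a change at this place can move the read-out beyond the scatter, which the earlier step with a readable floor did not show. Compound 4 gives >= 205 ug/mL, which is a limit. Nothing shown gives a measured reason for this step, which swaps a two-ring group carrying a hydrogen-bond donor for a one-ring group without one.

The steps that join compound 4 to compound 1 and to compound 2 cannot be read, and all three of these compounds carry limits. Going by these compounds, how this assay responds to an amine or a carboxylic acid in place of 3-methylphenyl on that saturated chain carbon remains open.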